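The source may hold more compounds than are shown below. What is called first, only, known or untested is meant among the compounds shown, and "the series" means these compounds.

Compound 1, `CNc1nc(NCCCN(C)C)c2sc(-c3ccc(S(C)(=O)=O)cc3)cc2n1`, gives 15 uL/min in an ADME assay (liver) for metabolic stability, with Liver microsome (Homo sapiens) as the target, read by LC-MS, using microsomes, tested at 1 uM; a higher number here means faster removal of the compound, a lower number slower removal.
Compound 2, `CNc1nc(NCCCN(C)C)c2sc(-c3ccc(OC)nc3)cc2n1`, gives 10 uL/min in this assay.

Going by the values given here, only two numbers exist so far, and compound 2 and compound 1 sit within the scatter of each other, so neither separates from the other. Compound 3, `CNc1nc(NCCCN(C)C)c2sc(-c3ccoc3)cc2n1`, carries furan-3-yl in place of 6-methoxypyridin-3-yl on an aromatic carbon. Among the compounds with values here, no measured pair shows this change, so nothing here anchors its size. In this assay the step is expected to be small, likely within the scatter, with no firm direction. For compound 3 the estimate is 14 uL/min, between 6 uL/min and 35 uL/min, meaning an expected step of a 1.4-fold higher number from compound 2 to compound 3 (0.15 log units; within the scatter).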

Compound 3, intrinsic clearance in a liver preparation (reported as CLH), per the amount of preparation that the assay uses: 33.3 uL/min
For compound 3 the middle estimate is 2.4-fold (0.38 log units) below the measured one, within the range that was stated.
By their numbers in this assay, from the lowest: compounds 2 and 1 (each within the scatter of the next); then compound 3.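

At the aromatic carbon next to the ring sulfur, the aryl group can move the read-out beyond the scatter: in this assay furan-3-yl in place of 6-methoxypyridin-3-yl gives a 3.3-fold higher number from compound 2 to compound 3 (0.52 log units; beyond the scatter), a modest step and the first in the series to clear the scatter. Nothing available explains this step. Still open, going by these compounds, is whether the smaller ring or the missing methoxy group accounts for the change, and whether a plain pyridin-3-yl or a thiophen-3-yl at this position would read closer to compound 2 or compound 3.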